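The source may report more compounds than this note shows. Statements on the series, on what has been measured and on what is new or still open speak of the compounds shown alone.

Compound 1 `CCCc1nc(-c2ccccc2)c(CNCCCN2CCN(c3cccc(F)c3)CC2)o1` gives the lowest number of the two compounds measured in an assay on HEK293 cells for inhibition of Voltage-dependent T-type calcium channel subunit alpha-1G (Homo sapiens), read by patch clamp; on this read-out lower numbers stand for stronger inhibition and higher numbers for weaker inhibition: compound 1 gives 3030 nM, while compound 2 `CCCc1nc(-c2ccccc2)c(CNCCN2CCN(c3ccccc3)CC2)o1` gives 10300 nM, a gap beyond the usual scatter. Compound 3 `CCCc1nc(-c2ccccc2)c(CNCCCN2CCN(c3cccc(C)c3)CC2)o1` differs from compound 1 in a single place: methyl in place of fluoro on an aromatic carbon. Within the data shown here, no measured pair shows this exact change, so nothing sets its size directly. The step of a 1.0-fold lower number from compound 1 to compound 3 (0.00 log units; within the scatter) is expected to be none beyond the scatter. Compound 3 is therefore estimated at 3000 nM, within a range from 1200 nM to 8000 nM.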

Compound 3, half-maximal inhibitory concentration: 1190 nM
The estimate for compound 3 lay 2.5-fold (0.40 log units) above the measured number; measured number below the stated range.
By their numbers in this assay, from the lowest: compound 3; then compound 1; then compound 2.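

In this assay, methyl in place of fluoro gives a 2.5-fold lower number from compound 1 to compound 3 (0.41 log units; beyond the scatter) at this place on the aromatic ring. The number therefore responds to which group sits here, even though each group counts a single heavy atom and neither carries hydrogen-bond donors or acceptors. No measurement shown here gives a reason for this step. Going by these compounds, whether a larger group such as chloro, methoxy or trifluoromethyl would lower the number further remains open. So does whether methyl would give a similar step elsewhere on the ring.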